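A few compounds are considered here, and "the series" means these few. Any claim that something is new, unique, unknown or untested is made for them only; others in the source may bear on it.

The cytotoxicity series rests on three compounds, each read out in an ADME assay on HFF cells (Homo sapiens) for cytotoxicity, with a stated time of 8 days; on this read-out lower numbers stand for higher toxicity in this test and higher numbers for lower toxicity in this test. Going by the values given here, compound 1, `CCCCCCCCOc1nc(N)nc2c1ncn2/C=C1/CC1(CO)CO`, is the first of them. In this assay compound 1 reaches only a limit, > 300000 nM. Compound 2, `CCCSc1nc(N)nc2c1ncn2/C=C1/CC1(CO)CO`, follows. In this assay compound 2 likewise gives only a limit, > 300000 nM. Compound 3, `Nc1nc(NC2CCCCC2)c2ncn(/C=C3/CC3(CO)CO)c2n1`, stands in the same place. In this assay compound 3 gives only a limit, > 300000 nM. The steps among them are therefore not readable: a step that the two limits leave unreadable from compound 1 to compound 2, a step that the two limits leave unreadable from compound 1 to compound 3 and a step that the two limits leave unreadable from compound 2 to compound 3. All that is known is the limit of > 300000 nM in this assay, at which 3 of the 3 values shown sit.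

The next compound is compound 4, `Nc1nc(SCc2ccccc2)c2ncn(/C=C3/CC3(CO)CO)c2n1`. Its change from compound 3 is benzylsulfanyl in place of cyclohexylamino on an aromatic carbon. Among the compounds with values here, none of the measured steps can size this change, since every one of them is hidden behind the same limit. With three compounds all sitting at the limit, the expectation for compound 4 is that it will be there too. Compound 4 is therefore estimated at 400000 nM, with a range from 100000 nM to 1500000 nM. The expected step from compound 3 is a step that the limit leaves unreadable from compound 3 to compound 4, no change beyond the scatter.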

Compound 4, half-maximal cytotoxic concentration: > 300000 nM
Compound 4 was reported as a limit (the forecaster's own chance of this, stated with the estimate: 75%); the middle value lies beyond the limit too.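

In this assay compound 4 gives > 300000 nM, which is again a limit. Its steps from compound 1, compound 2 and compound 3 therefore cannot be read: the limit of > 300000 nM in this assay, at which 4 of the 4 values shown sit.

The compounds shown leave open how far apart these four lie, and which change on the shared core, if any, would give a measurable value.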